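A few compounds are considered here, and "the series" means these few. Any claim that something is new, unique, unknown or untested is made for them only; others in the source may bear on it.

Compound 1 `C=C[C@@]1(C)O[C@H]1C[C@H]1C(=C)CC[C@@H]2[C@]1(C)CCC[C@]2(C)C(=O)O` sits at the edge of what the measurements can show. In a functional assay on MCF7 cells (Homo sapiens) for cytotoxicity, read by MTT assay, with a stated time of 48 h (a higher number here means a weaker inhibitor, a lower number a stronger inhibitor), compound 1 gives > 40000 nM, and this is a limit of the assay rather than a measured number (the limit of > 40000 nM in this assay, at which 1 of the 3 values shown sits).

Two other compounds, compound 2 `C=CC(=C)CC[C@@H]1[C@@]2(C)CCC[C@](C)(COC(=O)/C=C/c3ccc(O)cc3)[C@@H]2CC[C@@]1(C)O` and compound 3 `C=CC(=C)CC[C@@H]1[C@@]2(C)CCC[C@](C)(COC(=O)/C=C/c3ccc(O)c(OC)c3)[C@@H]2CC[C@@]1(C)O`, are built on a different skeleton and carry an aromatic ring that compound 1 lacks. In this assay compound 2 gives 16600 nM, and compound 3 gives 13500 nM. Among the measured compounds shown here, the only measured step between neighbours, a 1.2-fold lower number from compound 2 to compound 3 (0.09 log units; within the scatter), is a methoxy in place of hydrogen on an aromatic carbon, and it does not reach beyond the scatter.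

Compound 4 `C=C[C@@](C)(O)CC[C@H]1C(=C)CC[C@@H]2[C@]1(C)CCC[C@]2(C)C(=O)O` is compound 1 with one change: a group of 6 heavy atoms (5 carbon, 1 oxygen; no ring) in place of a group of 6 heavy atoms (5 carbon, 1 oxygen; one three-membered non-aromatic ring with 1 hetero atom), on a saturated chain carbon bound to a saturated ring carbon. The ring-bearing group gives way to the open-chain 2-hydroxy-2-methylbut-3-en-1-yl group, sitting on a saturated chain carbon bound to a saturated ring carbon.

For the measured compounds named here, no measured step touches this kind of change; the one step on record concerns an aromatic substituent on another skeleton. No movement beyond the scatter is therefore expected, and the step from compound 1 to compound 4 is estimated as a step that the limit leaves unreadable from compound 1 to compound 4. Compound 4 is expected to give about 50000 nM in this assay, with a range from 20000 nM to 150000 nM.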

Compound 4, half-maximal inhibitory concentration: > 40000 nM
Compound 4 ended at the assay's limit (the forecaster's own chance of this, stated with the estimate: 70%); the middle value lies beyond the limit too.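

In this assay compound 4 gives > 40000 nM, which is a limit of the assay and not a number. No step from compound 1 to compound 4 can be read, because both compounds stand at a limit: the limit of > 40000 nM in this assay, at which 2 of the 4 values shown sit.

The compounds shown leave open whether replacing the ring-bearing group with the 2-hydroxy-2-methylbut-3-en-1-yl group changes potency at all.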